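This account rests on a few compounds, and the source may have more. Where it says the series, first, only, none or still open, it means among the compounds named here.

Working notes on the series. Of the compounds shown here, two have been measured in a functional assay on Bel7402/5-FU cells (Homo sapiens) for antiproliferative activity, read by MTT assay, with a stated time of 72 h; a higher number here means a weaker inhibitor, a lower number a stronger inhibitor. Compound 1 `COc1cccc(CNCc2c(C(=O)O)n(Cc3ccc(O)cc3)c3cc(C(C)C)ccc23)c1` reports only a limit in this assay: compound 1 gives > 50000 nM, which is a limit of the assay and not a number, so compound 1 stands at the limit of > 50000 nM in this assay, at which 1 of the 2 values shown sits. Compound 2 `COc1ccc(Cn2c(C(=O)O)c(CNCc3ccc(O)c(OC)c3)c3ccc(C(C)C)cc32)cc1` is the other member measured; in this assay compound 2 gives 7900 nM; the two values are not joined by a single-point change, so only the two numbers themselves can be read. Compound 3 `COc1cccc(CNCc2c(C(=O)O)n(Cc3ccccc3)c3cc(C(C)C)ccc23)c1` is not yet measured. It differs from compound 1 by hydrogen in place of hydroxy on an aromatic carbon, that is, 4-hydroxybenzyl to benzyl on the shared core. For the measured compounds named here, no measured step covers this change, and compound 1 itself sits at the limit, so little can be anchored. The step from compound 1 to compound 3 is expected to be a number no higher from compound 1 to compound 3 (the limit leaves the size open), with no shift beyond the scatter anticipated. Compound 3 is therefore estimated at 50000 nM in this assay, within 15000 nM to 150000 nM, with a fair chance that only a limit is again reported.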

Compound 3, half-maximal inhibitory concentration: 5920 nM
Estimate against measurement, compound 3: 8.4-fold (0.93 log units) above; measured number below the stated range.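

In this assay, for the compounds shown here, hydrogen in place of hydroxy on the aromatic carbon of the 4-hydroxybenzyl group gives an at least 8.4-fold lower number from compound 1 to compound 3 (0.92 log units; beyond the scatter), the only single-point step so far. This position, para to a large group, therefore responds to the change, and the benzyl compound is the stronger inhibitor of the pair. The size of the step remains a lower bound, because compound 1 reports a limit of the assay and not a number: the limit of > 50000 nM in this assay, at which 1 of the 3 values shown sits.

On these data alone, whether an amine or a fluorine on this same aromatic carbon would read like hydrogen or like hydroxy remains open. Also open, as far as these compounds go, is whether the same step would hold on a core carrying a different group in place of the methoxy on the other benzyl ring.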